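Ether substituent series: estimate for the benzyl ether

The source may hold more compounds than are shown below. What is called first, only, known or untested is meant among the compounds shown, and "the series" means these compounds.

Measured so far:
compound 1, `CC(C)Oc1cncc(C2=CC3CNCC(C2)C3)c1`, 4.8 nM
compound 2, `Clc1ccc(Oc2cncc(C3=CC4CNCC(C3)C4)c2)cc1`, 40 nM
compound 3, `COc1cncc(C2=CC3CNCC(C2)C3)c1`, 14.3 nM

In an in vitro assay on SH-SY5Y cells for displacement of a labelled ligand from Neuronal acetylcholine receptor; alpha3/beta4 (Homo sapiens) (a lower number here means a stronger inhibitor, a higher number a weaker inhibitor), compound 3 stands second highest of the three numbers, set apart from both neighbours by steps beyond the scatter: a 3.0-fold higher number from compound 1 to compound 3 (0.47 log units; beyond the scatter) and a 2.8-fold lower number from compound 2 to compound 3 (0.45 log units; beyond the scatter). Compound 4, `C1=C(c2cncc(OCc3ccccc3)c2)CC2CNCC1C2`, is not yet measured; it differs from compound 3 by phenyl in place of hydrogen on a saturated chain carbon bound to an oxygen on an aromatic ring. Both measured steps alter the group on the oxygen on the aromatic ring, are modest, and run in opposite directions, so the data do not fix the direction for a benzyl group. Compound 2, which also carries a six-membered aromatic ring on that oxygen, gives the highest number; on that basis the step of a 2.1-fold higher number from compound 3 to compound 4 (0.32 log units; beyond the scatter) is expected to be a modest rise. Compound 4 is expected to give 30 nM, within 8 nM to 120 nM.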

Compound 4, inhibition constant: 44 nM
Estimate against measurement, compound 4: 1.5-fold (0.17 log units) below; the measured number falls inside the stated range.
By their numbers in this assay, from the lowest: compound 1; then compound 3; then compounds 2 and 4 (each within the scatter of the next).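

In this assay the step of a 3.1-fold higher number from compound 3 to compound 4 (0.49 log units; beyond the scatter) shows that extending methyl to benzyl on this oxygen raises the number, while the step of a 1.1-fold higher number from compound 2 to compound 4 (0.04 log units; within the scatter) leaves benzyl and 4-chlorophenyl unseparated. The step of a 9.2-fold higher number from compound 1 to compound 4 (0.96 log units; beyond the scatter) puts benzyl with 4-chlorophenyl on the weaker side of both isopropyl and methyl in this set of ethers. No evidence on hand accounts for these steps.

Open, on these data alone, is how a longer chain such as phenethyl on this oxygen would read. Also open, as far as these compounds go, is whether a chlorine or an amine on the benzyl phenyl ring would shift the number.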